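This account rests on a few compounds, and the source may have more. Where it says the series, first, only, none or still open, it means among the compounds named here.

Compound 1 `COc1ccc(C(=O)c2ccc(OC)c3c2C=CC(C)(C)O3)c(NC(=O)CBr)c1`: 4360 nM
Compound 2 `COc1ccc(C(=O)c2ccc(OC)c3c2C=CC(C)(C)O3)c(NC(=O)CO)c1`: 630 nM
Compound 3 `COc1ccc(C(=O)c2ccc(OC)c3c2C=CC(C)(C)O3)c(NC(=O)CN)c1`: 1050 nM

All three values come from a functional assay on HCT-8 cells (Homo sapiens) for antiproliferative activity, read by MTT assay, with a stated time of 48 h (on this read-out higher numbers stand for weaker inhibition and lower numbers for stronger inhibition), and the compounds differ only in the group on a saturated chain carbon bound to a carbonyl carbon. On these numbers, the amino compound sits with the hydroxy compound, as the measured step is a 1.7-fold higher number from compound 2 to compound 3 (0.22 log units; within the scatter). Both stand apart from the bromo compound, with steps of a 4.2-fold lower number from compound 1 to compound 3 (0.62 log units; beyond the scatter) and a 6.9-fold lower number from compound 1 to compound 2 (0.84 log units; beyond the scatter).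

Compound 4 `CNCC(=O)Nc1cc(OC)ccc1C(=O)c1ccc(OC)c2c1C=CC(C)(C)O2` keeps the whole of compound 3 except for one change: methyl in place of hydrogen on an amine nitrogen. Among the compounds with values here, no measured step alters this nitrogen, so the evidence is indirect. The closest comparison is the exchange of hydroxy for amino, which stayed within the scatter, while the two modest steps both involve the loss of bromo, a larger exchange than the one here. No step beyond the scatter is therefore expected in this assay, and neither direction is favoured. The expected step is a 1.1-fold lower number from compound 3 to compound 4 (0.02 log units; within the scatter). Compound 4 is estimated at 1000 nM, with an expected range of 400 nM to 2600 nM.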

Compound 4, half-maximal inhibitory concentration: 3460 nM
Compound 4: the middle estimate sits 3.5-fold (0.54 log units) below what was measured; measured number outside the range, above it.
By their numbers in this assay, from the lowest: compounds 2 and 3 (each within the scatter of the next); then compounds 4 and 1 (each within the scatter of the next).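

In this assay the amine nitrogen on the saturated chain carbon proves responsive to a single added methyl: methyl in place of hydrogen gives a 3.3-fold higher number from compound 3 to compound 4 (0.52 log units; beyond the scatter) as a modest step, whereas the earlier exchange of hydroxy for amino stayed within the scatter. Within the data shown here, the methylamino group parts from hydroxy with a 5.5-fold higher number from compound 2 to compound 4 (0.74 log units; beyond the scatter) but stays level with bromo at a 1.3-fold lower number from compound 1 to compound 4 (0.10 log units; within the scatter) and so joins the group that the earlier compounds had left on its own, which means the pairing with hydroxy holds for amino and not for methylamino. A nitrogen at this position is thus not enough to place a compound with the hydroxy compound, as the two nitrogen groups stand on opposite sides of the gap, and nothing measured here accounts for the difference.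

The compounds shown leave open whether a dimethylamino group or an ethylamino group would follow the methylamino compound or return towards the amino compound. They also leave open how a ring amine such as morpholine, or a methoxy group in place of hydroxy, would read at this position.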